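The compounds below may be only part of what the source reports. "The series", "measured", "known", "first", "only" and "open" are said of these compounds alone.

Working notes on the series.

Compound 1 `CC[C@H](C)[C@H](NC(=O)CN(c1nc(Cl)nc2[nH]cnc12)C1CC1)C(=O)O` is the reference point. In a functional assay on the whole organism (Tail, strain ICR) with Mus musculus as the target, in the tail flick test, with a stated time of 30 min, at a dose of 25 umol/kg by the oral route (a lower number here means a weaker effect, a higher number a stronger effect of the compound at the dose given), compound 1 gives 30.3%. Compound 3 `C[C@@H](O)[C@H](NC(=O)CN(c1nc(Cl)nc2[nH]cnc12)C1CC1)C(=O)O` carries the same core and differs by one change, (hydroxy in place of ethyl on a saturated chain carbon bound to two saturated chain carbons). In this assay compound 3 gives 18.6%, so the step is a number 11.7 percentage points lower from compound 1 to compound 3 (beyond the scatter).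

Compound 2 `CC[C@H](C)[C@H](NC(=O)CN(c1ncnc2c1ncn2C1CCCCO1)C1CC1)C(=O)OCc1ccccc1` stands on a different core; how the core of compound 2 differs from the core of compound 1 is not broken down here. In this assay compound 2 gives 25.6%, which the scatter does not separate from the value of compound 1 or from that of compound 3.

Compound 4 `C[C@@H](O)[C@H](NC(=O)CN(c1ncnc2c1ncn2C1CCCCO1)C1CC1)C(=O)OCc1ccccc1` is not yet measured. It differs from compound 2 by hydroxy in place of ethyl on a saturated chain carbon bound to two saturated chain carbons. The place reads word for word as it does for the change from compound 1 to compound 3, so this is the same change made on the second core; it occurs twice in all among the compounds shown.

Expected behaviour: the step from compound 2 to compound 4 in this assay is estimated at a number 10.6 percentage points lower from compound 2 to compound 4 (beyond the scatter), resting on the only earlier instance of this change, because the earlier instance read a number 11.7 percentage points lower from compound 1 to compound 3 (beyond the scatter). Whether a second core carries the change the same way is not shown by any other pair here, so the range is kept wide. For compound 4 the expected value in this assay is 15%, with a range from 4% to 27%.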

Compound 4, a percentage reported as activity, at one dose (the size of the read-out at that dose, not a potency): 23.6%
For compound 4 the middle estimate is 8.6 percentage points below the measured one, within the range that was stated.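

In this assay, going by these compounds alone, hydroxy in place of ethyl on the core of compound 2 gives a number 2 percentage points lower from compound 2 to compound 4 (within the scatter), so on this core the change produces no step that can be told from repeat measurement. Set beside the earlier instance, the two steps are not separated, and the drop seen on the first core therefore cannot be said to differ from the result on the second: the same change on two cores in this assay, a number 11.7 percentage points lower (beyond the scatter) from compound 1 to compound 3 and a number 2 percentage points lower (within the scatter) from compound 2 to compound 4, 9.7 percentage points apart, within the scatter of two such steps

Within the data shown here, this fits a change that carries from one core to the other, but it does not show that the step is the same size on both, nor that the second core weakens it, as only two pairs bear on the question, one beyond the scatter and one within it, and each rests on a read-out at a single dose.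

The compounds shown leave open how an amine, a methoxy group or a longer chain would read in place of ethyl on a saturated chain carbon bound to two saturated chain carbons, on either core. They also leave open whether the change from sec-butyl to 1-hydroxyethyl would give a step of either size on any further core.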